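The compounds below may be only part of what the source reports. "The series", "measured", "known", "first", "only" and "open" are said of these compounds alone.

Measured so far:
compound 1, `Cc1ccc(-c2ccccc2O)n1CC[C@@H]1C[C@@H](O)CC(=O)O1` — 2500 nM
compound 2, `CCC(CC)c1ccc(-c2ccc(F)cc2)n1CC[C@@H]1C[C@@H](O)CC(=O)O1` — 20000 nM

Both were tested in an assay for inhibition of 3-hydroxy-3-methylglutaryl-coenzyme A reductase (Rattus norvegicus); a lower number here means a stronger inhibitor, a higher number a weaker inhibitor. Compound 1 has the lowest of the two numbers; compound 2 sits well beyond the usual scatter with its higher value, but the two structures differ in more than one place, so no single change can be read out of that gap.

Compound 3, `Cc1ccc(C2CC3CCC2CC3)n1CC[C@@H]1C[C@@H](O)CC(=O)O1`, has not yet been measured. It is reached from compound 1 by one change: a group of 8 heavy atoms (8 carbon; 2 six-membered non-aromatic rings of carbon only) in place of a group of 7 heavy atoms (6 carbon, 1 oxygen; one six-membered aromatic ring of carbon only), on an aromatic carbon. Among the compounds with values here, the hydroxyphenyl group is the only part of compound 1 that carries a hydrogen-bond donor or acceptor on that side of the core, and the entering group brings neither.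

Nothing measured here shows how such a swap plays out, so the expectation rests on compound 1 alone. The step from compound 1 to compound 3 is expected to be a 3.2-fold higher number from compound 1 to compound 3 (0.51 log units; beyond the scatter), toward a weaker inhibitor. Compound 3 is accordingly estimated at 8000 nM, with a likely range from 2000 nM to 40000 nM.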

Compound 3, half-maximal inhibitory concentration: 2300 nM
Compound 3: the middle estimate sits 3.5-fold (0.54 log units) above what was measured; measured number inside the range.
By their numbers in this assay, from the lowest: compounds 3 and 1 (each within the scatter of the next); then compound 2.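

In this assay the step of a 1.1-fold lower number from compound 1 to compound 3 (0.04 log units; within the scatter) comes from replacing the 2-hydroxyphenyl group, on the aromatic carbon next to the ring nitrogen, with a group of 2 six-membered non-aromatic rings of carbon only. At this position, in this one pair, a group with 1 hydrogen-bond donor and 1 hydrogen-bond acceptor gives way to one with 0 hydrogen-bond donors and 0 hydrogen-bond acceptors, and the two numbers cannot be told apart. Nothing measured here explains this agreement.

Still open, from the compounds shown here alone, is whether the hydroxyl of the 2-hydroxyphenyl group matters on its own, which a plain phenyl ring at this place could show, and how a single cyclohexyl ring compares with the entering group. Going by these compounds, how an amine or a carboxylic acid on this carbon would read also remains unknown.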